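Aryl urea series: a methoxy in place of a nitro

The source may hold more compounds than are shown below. What is called first, only, known or untested is meant among the compounds shown, and "the series" means these compounds.

compound 1, `Cc1cc(NC(=O)Nc2ccccc2C(F)(F)F)c2ccccc2n1`: > 25000 nM in an ADME assay on Raji cells (Homo sapiens) for cytotoxicity, with a stated time of 72 h (on this read-out higher numbers stand for an effect only at larger amounts of compound and lower numbers for an effect already at smaller amounts), a limit of the assay
compound 2, `Cc1cc(NC(=O)Nc2ccccc2C(N)=O)c2ccccc2n1`: > 25000 nM in this assay, a limit of the assay
compound 3, `Cc1cc(NC(=O)Nc2ccccc2[N+](=O)[O-])c2ccccc2n1`: > 25000 nM in this assay, a limit of the assay

Compound 3 stands at the limit of the assay, and so do the two other values shown (the limit of > 25000 nM in this assay, at which 3 of the 3 values shown sit). The three steps between the measured compounds are therefore unreadable: a step that the two limits leave unreadable from compound 1 to compound 2, a step that the two limits leave unreadable from compound 1 to compound 3 and a step that the two limits leave unreadable from compound 2 to compound 3. None of them gives a size or a direction.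

The compound not yet measured is compound 4, `COc1ccccc1NC(=O)Nc1cc(C)nc2ccccc12`. It differs from compound 3 as follows: methoxy in place of nitro on an aromatic carbon.

No measured step can be read to bear on this change; all that the series shows is that a trifluoromethyl, a carbamoyl and a nitro at this place each leave the compound at the limit. On that basis no step beyond the scatter is expected in this assay, and compound 4 is expected to sit at the limit as well because of the limit of > 25000 nM in this assay, at which 3 of the 3 values shown sit. Compound 4 is estimated at 30000 nM, with a range from 10000 nM to 100000 nM. The step this estimate means is a step that the limit leaves unreadable from compound 3 to compound 4, which is expected to stay within the scatter.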

Compound 4, half-maximal effective concentration: > 25000 nM
Compound 4 ended at the assay's limit (the forecaster's own chance of this, stated with the estimate: 80%); the middle value does not contradict the limit.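

In this assay compound 4 gives > 25000 nM, a limit of the assay. Within the data shown here, its steps from compound 1, compound 2 and compound 3 cannot be read, so no new step follows from this result. The compounds shown leave open whether any of these four groups on the shared core differs from another in this read-out.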